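This account rests on a few compounds, and the source may have more. Where it says the series, first, only, none or still open, it means among the compounds named here.

Compound 1 `COc1ccc(C2=NN(c3ccc(Cl)cc3)C(c3ccc(Cl)cc3)C2)cc1OC` — 39.4%
Compound 2 `COc1ccc(C2=NN(c3cccc(Cl)c3)C(c3cccc(Cl)c3)C2)cc1` — 25.3%
Compound 3 `COc1ccc(C2=NN(c3ccc(Cl)cc3)C(c3ccc(Cl)cc3)C2)c(OC)c1` — 28.6%

Of the compounds shown here, three built on a shared core have been measured in an assay on HEK293 cells for inhibition of protein kinase C zeta type (Homo sapiens), read by 33P incorporation, with a stated time of 40 min, tested at 20 uM, in the presence of a further agent that is not named here; on this read-out higher numbers stand for more inhibition at the one concentration tested (going by the name of the read-out) and lower numbers for less inhibition. Compound 1 stands highest of the three numbers. Its nearest neighbour is compound 3, whose value lies lower by a margin beyond the usual scatter; compound 2 lies lower still, again beyond the scatter. Within the data shown here, no two of the measured compounds differ in only one place, so no single step between them can be read off.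

Compound 4 `COc1cccc(C2=NN(c3ccc(Cl)cc3)C(c3ccc(Cl)cc3)C2)c1` has not yet been measured in this assay. It differs from compound 1 in one place: hydrogen in place of methoxy on an aromatic carbon. Both measured compounds that carry fewer or differently placed methoxy groups than compound 1 gave smaller numbers, but neither of them is a one-step neighbour of compound 4, so this remains a loose guide.

The step from compound 1 to compound 4 is expected to run downward, by roughly a number 11.4 percentage points lower from compound 1 to compound 4 (beyond the scatter), a size beyond the scatter though not large. Compound 4 is estimated to give 28% in this assay, with a plausible range from 15% to 42%.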

Compound 4, a percentage reported as inhibition, at one concentration (the size of the read-out at that concentration, not a potency): 17.9%
Compound 4: middle estimate off by 10.1 percentage points, on the high side; low and high end bracket the measured number.
By their numbers in this assay, from the lowest: compounds 4, 2 and 3 (each within the scatter of the next, the first and the last beyond it); then compound 1.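

In this assay, among these compounds, hydrogen in place of methoxy gives a number 21.5 percentage points lower from compound 1 to compound 4 (beyond the scatter), the first comparison in this set in which a single place changes while the rest of the structure stays the same. Among the compounds shown here, this ties a loss of inhibition at the one concentration tested to this particular methoxy, the one ortho to a methoxy group and para to a large group on the six-membered aromatic ring of carbon only, which the earlier compounds could not do because each of them differs from the others in more than one place. Nothing available here bears on why the number falls with this change.

On these data alone, it remains open whether the methoxy itself matters at this carbon or whether another group would serve as well, such as a hydroxyl, an ethoxy, a fluorine or an amine. As far as these compounds go, it is also open whether the same change would give a step of similar size with the chlorine atoms placed as in compound 2, and, as each number comes from a single concentration, how the step would translate into potency.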